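From amino to chloro on a shared core

The source may hold more compounds than are shown below. What is called first, only, known or untested is meant among the compounds shown, and "the series" means these compounds.

Measured in an ADME assay on L1210/0 cells (Mus musculus) for cytotoxicity, with a stated time of 48 h; on this read-out higher numbers stand for weaker inhibition and lower numbers for stronger inhibition:
Compound 1 `COC1=C(OC)C(CCn2cnc3c(N)ncnc32)(/[S+]=C/C(NC(C)=O)C(=O)O)OC1=O` gives > 200000 nM
Compound 2 `COC1=C(OC)C(O)(CCn2cnc3c(N)ncnc32)OC1=O` gives > 200000 nM

Compound 2 stands at > 200000 nM as a limit and not a number. Compound 1 also gives a limit with > 200000 nM as its entry. Both rest on the limit of > 200000 nM in this assay, at which 2 of the 2 values shown sit, and on nothing firmer. Compound 3 `COC1=C(OC)C(O)(CCn2cnc3c(Cl)ncnc32)OC1=O` has chloro in place of amino on an aromatic carbon and awaits measurement. Among the compounds with values here, the one measured step is a step that the two limits leave unreadable from compound 1 to compound 2 at a different group, so it offers no size to carry over. Compound 2 with > 200000 nM leaves room for a readable result only toward stronger inhibition. The expected step is an at least 1.6-fold lower number from compound 2 to compound 3 (0.22 log units; that floor lies within the scatter) in that direction, with its size uncertain. For compound 3 the estimated value is 120000 nM with an expected range from 25000 nM to 200000 nM in this assay for now.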

Compound 3, half-maximal inhibitory concentration: > 200000 nM
Compound 3 gave a limit, no number (the forecaster's own chance of this, stated with the estimate: 50%); middle value at least 1.6-fold (0.22 log units) away from the limit.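

Within the data shown here, compound 2 and compound 3 both rest on a limit and not a number, leaving no step readable between them: the limit of > 200000 nM in this assay, at which 3 of the 3 values shown sit. The compounds shown leave open whether chloro in place of amino changes the inhibition at all.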